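Oxygen-to-sulfur swap on the aryl link of compound 1

A few compounds are considered here, and "the series" means these few. Any claim that something is new, unique, unknown or untested is made for them only; others in the source may bear on it.

Measured so far:
compound 1 `Nc1cc(N)c2nc(-c3ccccc3)c(Oc3ccc(Cl)c(Cl)c3)nc2c1` — 89100 nM
compound 2 `CCOC(=O)[C@H](CCC(=O)O)NC(=O)c1ccc(Sc2nc3cc(N)cc(N)c3nc2-c2ccccc2)cc1` — 39800 nM

Among the compounds with values here, in a functional assay on OVCAR-8 cells (Homo sapiens) for inhibition, read by sulforhodamine B assay, with a stated time of 48 h (on this read-out higher numbers stand for weaker inhibition of growth and lower numbers for stronger inhibition of growth), compound 1 gives 89100 nM, the highest of the two numbers in hand; the only neighbour, compound 2, gives 39800 nM, a number that sits beyond the scatter below it. Both compounds share the same core, and compound 2 carries its own substituent on it, so nothing in these two values speaks directly to the change considered here.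

Compound 3 `Nc1cc(N)c2nc(-c3ccccc3)c(Sc3ccc(Cl)c(Cl)c3)nc2c1` differs from compound 1 in one place: (3,4-dichlorophenyl)sulfanyl in place of 3,4-dichlorophenoxy on an aromatic carbon. Within the data shown here, no pair of measured compounds shows this exact change, so the step is a guess: a small one in this assay, if anything toward lower numbers, and quite possibly within the scatter. Compound 3 is therefore expected at 60000 nM, with a plausible range from 25000 nM to 150000 nM, which would mean an estimated step of a 1.5-fold lower number from compound 1 to compound 3 (0.17 log units; within the scatter).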

Compound 3, concentration for total growth inhibition: < 100000 nM
Compound 3: no number, only a limit (the forecaster's own chance of this, stated with the estimate: 10%); the middle value is on the limit's open side.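

Within the data shown here, compound 3 gives only a limit in this assay, < 100000 nM and not a number, so no step from compound 1 to compound 3 can be read. On these data alone, whether (3,4-dichlorophenyl)sulfanyl in place of 3,4-dichlorophenoxy on the shared core changes growth inhibition, and in which direction, stays open.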